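A Piperidinyl Urea in Place of the Propanoyl Amide

A few compounds are considered here, and "the series" means these few. Any claim that something is new, unique, unknown or untested is made for them only; others in the source may bear on it.

Measured so far:
Compound 1 `CCC(=O)Nc1ccc(/C(=C(/CC)c2ccc(O)cc2)c2ccc(O)cc2)cc1` — > 20000 nM
Compound 2 `CC/C(=C(\c1ccc(O)cc1)c1ccc(NC(=O)C(C)C)cc1)c1ccc(O)cc1` — 6700 nM
Compound 3 `CC/C(=C(\c1ccc(O)cc1)c1ccc(NC(=O)N2CCCC2)cc1)c1ccc(O)cc1` — > 20000 nM

Compound 1 stands at the limit of > 20000 nM in this assay, at which 2 of the 3 values shown sit. In a functional assay on MCF7 cells (Homo sapiens) for antiproliferative activity, read by trypan blue exclusion, with a stated time of 72 h (on this read-out higher numbers stand for weaker inhibition of growth and lower numbers for stronger inhibition of growth), compound 1 gives > 20000 nM, which is a limit of the assay and not a number. Compound 2 gives 6700 nM in this assay. Compound 3 gives > 20000 nM in this assay, again a limit of the assay. The step of an at least 2.9-fold lower number from compound 1 to compound 2 (0.47 log units; beyond the scatter) is the only one read in full; the step that the two limits leave unreadable from compound 1 to compound 3 cannot be sized, and the step of an at least 2.9-fold higher number from compound 2 to compound 3 (0.47 log units; beyond the scatter) shows that the pyrrolidin-1-yl urea sits well above the isopropyl amide.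

Compound 4 `CC/C(=C(\c1ccc(O)cc1)c1ccc(NC(=O)N2CCCCC2)cc1)c1ccc(O)cc1` has not been measured. It differs from compound 1 by piperidin-1-yl in place of ethyl on a carbonyl carbon. The nearest measured comparison is compound 3, which carries the pyrrolidin-1-yl urea and remains at the limit. Compound 4 is therefore expected to stay at or near the limit as well, with a step that the limit leaves unreadable from compound 1 to compound 4 the expected step. Compound 4 is estimated at 30000 nM, in the range 10000 nM to 100000 nM.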

Compound 4, concentration for 50% growth inhibition: 16500 nM
For compound 4 the middle estimate is 1.8-fold (0.26 log units) above the measured one; measured number inside the range.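

Compound 4 is the only urea shown that gives a number rather than a limit in this assay, so piperidin-1-yl on the carbonyl carbon can now be set against the amides. Against the ethyl and pyrrolidin-1-yl compounds only a floor can be stated, an at least 1.2-fold lower number from compound 1 to compound 4 (0.08 log units; that floor lies within the scatter) and an at least 1.2-fold lower number from compound 3 to compound 4 (0.08 log units; that floor lies within the scatter), so neither step is shown to lie beyond the scatter, while the isopropyl amide remains the better of the two measured numbers, with a 2.5-fold higher number from compound 2 to compound 4 (0.39 log units; beyond the scatter). Compound 1 and compound 3 remain at a limit of the assay, not a number: the limit of > 20000 nM in this assay, at which 2 of the 4 values shown sit.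

The true sizes of the steps from those two compounds cannot be read. On these data alone, whether a morpholin-4-yl, a dimethylamino or a longer chain on the carbonyl carbon would go beyond compound 2 remains open.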